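The source may report more compounds than this note shows. Statements on the series, on what has been measured and on what is new or still open speak of the compounds shown alone.

In a physicochemical assay for metabolic stability, read by HPLC and mass spectrometry, in phosphate buffer, at 37 degrees C, at pH 7.4 (on this read-out higher numbers stand for a longer-lived compound and lower numbers for a shorter-lived compound), compound 3 `C[C@@H]1CN(C[C@@H]2[C@H](NC(=O)/C(=N\OC(C)(C)C(=O)O)c3csc(N)n3)C(=O)N2S(=O)(=O)O)C(=O)O1` gives > 37 h, which is a limit of the assay and not a number. Its true half-life is therefore unknown, and a step that the limit leaves unreadable from compound 1 to compound 3 and a step that the two limits leave unreadable from compound 2 to compound 3 cannot be sized. Compound 4 `CC(C)(O/N=C(\C(=O)N[C@@H]1C(=O)N(S(=O)(=O)O)[C@@H]1CN1C[C@H](CN)OC1=O)c1csc(N)n1)C(=O)O` is still to be measured. It differs from compound 3 as follows: 5-(aminomethyl)-2-oxo-1,3-oxazolidin-3-yl in place of 5-methyl-2-oxo-1,3-oxazolidin-3-yl on a saturated chain carbon bound to a saturated ring carbon. In words, 5-(aminomethyl)-2-oxo-1,3-oxazolidin-3-yl replaces 5-methyl-2-oxo-1,3-oxazolidin-3-yl on a saturated chain carbon bound to a saturated ring carbon.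

Within the data shown here, only one measured comparison offers guidance. Compound 1 `CN(C[C@@H]1[C@H](NC(=O)/C(=N\OC(C)(C)C(=O)O)c2csc(N)n2)C(=O)N1S(=O)(=O)O)C(=O)CN` gives 212 h, and it carries ((aminomethyl)carbonyl)(methyl)amino at that place. Compound 2 `CC(C)(O/N=C(\C(=O)N[C@@H]1C(=O)N(S(=O)(=O)O)[C@@H]1CN1CCCC1=O)c1csc(N)n1)C(=O)O` gives > 1000 h, also a limit of the assay. The readable step is an at least 4.7-fold higher number from compound 1 to compound 2 (0.67 log units; beyond the scatter), with 2-oxopyrrolidin-1-yl entering. That single pair suggests that a group bearing aminomethyl may sit lower in this assay, so a modest fall is expected if compound 3 lies well past its limit. The step this estimate means is an expected step that the limit leaves unreadable from compound 3 to compound 4. For compound 4, the half-life is expected to be near 100 h. The estimated range for compound 4 runs from 30 h to 350 h.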

Compound 4, half-life: > 37 h
Compound 4: no number, only a limit (the forecaster's own chance of this, stated with the estimate: 25%); the middle value does not contradict the limit.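

The steps from compound 1, compound 2 and compound 3 to compound 4 cannot be read in this assay, because compound 4 gives only a limit and no number: the limit of > 37 h in this assay, at which 2 of the 4 values shown sit.

The compounds shown leave open how far the half-lives of compound 3 and compound 4 lie past that limit, and so whether 5-(aminomethyl)-2-oxo-1,3-oxazolidin-3-yl and 5-methyl-2-oxo-1,3-oxazolidin-3-yl differ at all in this read-out.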